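A few compounds are considered here, and "the series" means these few. Any claim that something is new, unique, unknown or untested is made for them only; others in the source may bear on it.

Compound 1 `Cc1ccc(S(=O)(=O)N2C=CNC(=O)[C@H]2CC(=O)N[C@@H]2CCCc3ccccc32)cc1`: 3.3 nM
Compound 2 `Cc1ccc(S(=O)(=O)N2C=CNC(=O)[C@H]2CC(=O)N[C@H](C)c2ccccc2)cc1`: 836 nM

Both compounds share the same core and differ only in the group carried on an amide-type nitrogen. In an in vitro functional assay on cells for antagonist activity at B1 bradykinin receptor (Homo sapiens), read by luminescence and calcium flux, with a stated time of 2 h (a higher number here means a weaker inhibitor, a lower number a stronger inhibitor), compound 1 gives 3.3 nM, while compound 2 gives 836 nM, the highest of the two numbers, so compound 2 is the weaker inhibitor of the pair. Among the compounds with values here, the single measured step, a 250-fold higher number from compound 1 to compound 2 (2.40 log units; beyond the scatter), shows that this assay answers strongly to what sits on that nitrogen.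

Compound 3 `Cc1ccc(S(=O)(=O)N2C=CNC(=O)[C@H]2CC(=O)N[C@@H]2CCc3ccccc32)cc1` has not yet been measured in this assay. It differs from compound 2 in one place: 2,3-dihydro-1H-inden-1-yl in place of 1-phenylethyl on an amide-type nitrogen. The entering group, like the group in compound 1, contains a non-aromatic ring of carbon only in addition to the aromatic ring, whereas the leaving group has only the aromatic ring. The step from compound 1 to compound 2 is the only one that bears on this change, and it was large. Compound 3 is therefore expected to show a step of a 56-fold lower number from compound 2 to compound 3 (1.75 log units; beyond the scatter), recovering most of that difference. Compound 3 is estimated at 15 nM, with a range from 4 nM to 60 nM.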

Compound 3, half-maximal inhibitory concentration: 94.7 nM
Compound 3: the middle estimate sits 6.3-fold (0.80 log units) below what was measured, outside the stated range (above it).
By their numbers in this assay, from the lowest: compound 1; then compound 3; then compound 2.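

In this assay, replacing 1-phenylethyl with 2,3-dihydro-1H-inden-1-yl gives an 8.8-fold lower number from compound 2 to compound 3 (0.95 log units; beyond the scatter) and shows that a five-membered non-aromatic ring of carbon only, added to the aromatic ring, recovers part of what was lost on this amide-type nitrogen. The recovery is only partial, since the other comparison, a 29-fold higher number from compound 1 to compound 3 (1.46 log units; beyond the scatter) in the opposite sense of gain, separates the 1,2,3,4-tetrahydronaphthalen-1-yl group from the 2,3-dihydro-1H-inden-1-yl group, so among these three compounds the presence of a non-aromatic carbon ring does not settle the result on its own and the particular ring also counts. No measurement available here accounts for why these groups rank as they do.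

The compounds shown leave open whether a larger carbon ring, such as the seven-membered one in a 6,7,8,9-tetrahydro-5H-benzocyclohepten-5-yl group, would keep or lose the number seen for compound 1. They also leave open how a ring holding an oxygen atom, as in a chroman-4-yl group, or the opposite arrangement at the defined stereocentre of the group on this nitrogen, would behave in this assay when set on the same shared core.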